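The source may hold more compounds than are shown below. What is called first, only, known or untested is meant among the compounds shown, and "the series" means these compounds.

Measured so far in a functional assay on PC-3 cells (Homo sapiens) for inhibition, read by MTT assay, with a stated time of 48 h; a lower number here means a stronger inhibitor, a higher number a weaker inhibitor:
compound 1, `COc1cc(Nc2nc(Nc3ccc4c(ccn4C)c3)nnc2Cl)cc(OC)c1OC`, gives 48500 nM
compound 2, `COc1cc(Nc2nc(Nc3ccc(C)cc3)nnc2Cl)cc(OC)c1OC`, gives 14300 nM

For the measured compounds named here, compound 2 holds the lowest of the two numbers in this assay; its only neighbour is compound 1, and the step of a 3.4-fold lower number from compound 1 to compound 2 (0.53 log units; beyond the scatter) went with 4-methylphenyl in place of 1-methyl-1H-indol-5-yl on a nitrogen on an aromatic ring. Compound 3, `COc1cc(Nc2nc(Nc3ccccc3)nnc2Cl)cc(OC)c1OC`, has not yet been measured. It differs from compound 2 in one place: hydrogen in place of methyl on an aromatic carbon. Going by the values given here, no measured step bears directly on this change; the one known step swapped the whole ring system on that nitrogen, a much larger alteration than the loss of a single methyl, and it was only modest in size. On that basis compound 3 is expected to show a step of a 1.3-fold higher number from compound 2 to compound 3 (0.10 log units; within the scatter) that stays within the usual scatter, if anything leaning toward a slightly higher number. For compound 3 the expected value in this assay is 18000 nM, with a range from 7000 nM to 45000 nM.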

Compound 3, half-maximal inhibitory concentration: 9750 nM
Compound 3: middle estimate off by 1.8-fold (0.27 log units), on the high side, and the stated range covers the measured number.
By their numbers in this assay, from the lowest: compounds 3 and 2 (each within the scatter of the next); then compound 1.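

In this assay, hydrogen in place of methyl on an aromatic carbon, para to a large group, gives a 1.5-fold lower number from compound 2 to compound 3 (0.17 log units; within the scatter), so compound 2 and compound 3 cannot be told apart and the methyl at this position is not required for the level seen with compound 2. Phenyl in place of 1-methyl-1H-indol-5-yl on the nitrogen gives a 5.0-fold lower number from compound 1 to compound 3 (0.70 log units; beyond the scatter), which lies beyond the scatter, so the plain phenyl of compound 3 separates from compound 1 just as the 4-methylphenyl of compound 2 does in a 3.4-fold lower number from compound 1 to compound 2 (0.53 log units; beyond the scatter), and none of the three compounds goes against this. Nothing given here accounts for why the methyl makes so little difference at this position or why the 1-methyl-1H-indol-5-yl compound stands apart.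

With only methyl and hydrogen shown at this position, it remains open whether a methoxy group, a chlorine, an amine or a carboxylic acid there would shift the number beyond the scatter. From the compounds shown here alone, it also remains open whether a longer chain in place of the methyl would leave the number as it is, or whether any group at this position could bring it far below that of compound 3.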